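Methyl, fluoro and nitro sulfonamides, and the missing parent

The compounds below may be only part of what the source reports. "The series", "measured", "known", "first", "only" and "open" are said of these compounds alone.

Compound 1 `Cc1ccc(S(=O)(=O)N2c3ccccc3CCC2C)cc1` gives 4900 nM
Compound 2 `CC1CCc2ccccc2N1S(=O)(=O)c1cccc([N+](=O)[O-])c1` gives 187000 nM
Compound 3 `CC1CCc2ccccc2N1S(=O)(=O)c1ccc(F)cc1` gives 67600 nM

In an ADME assay on L6 cells (Rattus norvegicus) for cytotoxicity (on this read-out lower numbers stand for stronger inhibition and higher numbers for weaker inhibition), compound 3 holds the middle of the three numbers, with compound 2 higher and compound 1 lower. Compound 4 `CC1CCc2ccccc2N1S(=O)(=O)c1ccccc1` differs from it at one place: hydrogen in place of fluoro on an aromatic carbon. Among the measured compounds shown here, the only measured step at this place is a 14-fold higher number from compound 1 to compound 3 (1.14 log units; beyond the scatter), with fluoro in place of methyl. That step was large, but it does not involve hydrogen, so it bears on this change only indirectly. A modest move to a lower number is expected, much smaller than that step. The expected change is a 2.3-fold lower number from compound 3 to compound 4 (0.35 log units; beyond the scatter). Compound 4 is estimated at 30000 nM, with an expected range of 9000 nM to 90000 nM.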

Compound 4, half-maximal inhibitory concentration: 70000 nM
Estimate against measurement, compound 4: 2.3-fold (0.37 log units) below, within the range that was stated.
By their numbers in this assay, from the lowest: compound 1; then compounds 3 and 4 (each within the scatter of the next); then compound 2.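

In this assay, hydrogen and fluoro cannot be told apart at this position, with a 1.0-fold higher number from compound 3 to compound 4 (0.02 log units; within the scatter). The parent now gives the other two groups a direct reference: a 14-fold higher number from compound 1 to compound 4 (1.15 log units; beyond the scatter) for hydrogen in place of methyl, and a 2.7-fold lower number from compound 2 to compound 4 (0.43 log units; beyond the scatter) for hydrogen in place of nitro. Nothing available explains these differences.

On these data alone, whether the low number of compound 1 is particular to methyl remains open. An ethyl or methoxy group on the same aromatic carbon would test this, as would an amine.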